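The source may report more compounds than this note shows. Statements on the series, on what has been measured and on what is new or still open speak of the compounds shown alone.

Working notes on the series. In a functional assay on DWD cells (Homo sapiens) for inhibition, read by sulforhodamine B assay (a higher number here means a weaker inhibitor of growth, a lower number a stronger inhibitor of growth), compound 1 (`c1ccc(-c2ccc(-c3ccc(-c4nc5ccccc5[nH]4)cc3)cc2)cc1`) gives 100000 nM and compound 2 (`Clc1cccc(-c2ccc(-c3ccc(-c4nc5ccccc5[nH]4)cc3)cc2)c1`) gives 100000 nM. Compound 3 (`Oc1cccc2[nH]c(-c3ccc(-c4ccc(-c5ccccc5)cc4)cc3)nc12`) gives 9680 nM, the lowest of the three numbers and well beyond the scatter from both others.

The next change leads to compound 4 (`Oc1cccc2[nH]c(-c3ccc(-c4ccc(-c5ccc(OC(F)(F)F)cc5)cc4)cc3)nc12`), with trifluoromethoxy in place of hydrogen on an aromatic carbon, para to a large group: trifluoromethoxy in place of hydrogen on an aromatic carbon. Cut one bond further out, this reads phenyl to 4-(trifluoromethoxy)phenyl.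

For the measured compounds named here, two measured steps bear on this, neither directly. Chloro in place of hydrogen gave no change at the digits printed from compound 1 to compound 2 (within the scatter), so the only measured replacement by a group other than hydroxy left the number unmoved. Hydroxy in place of hydrogen gave a 10-fold lower number from compound 1 to compound 3 (1.01 log units; beyond the scatter), which is large, but it concerns a different group. It does not show what trifluoromethoxy will do. Going by the values given here, no measured compound carries trifluoromethoxy, and chloro was tested only without the hydroxy group, so the precedent is thin.

No step beyond the scatter is therefore expected in this assay, in either direction, though the uncertainty is wide. The estimated step is a 1.2-fold lower number from compound 3 to compound 4 (0.08 log units; within the scatter). For compound 4 the expected value is 8000 nM, with an estimated range of 2500 nM to 30000 nM.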

Compound 4, concentration for 50% growth inhibition: 3100 nM
The estimate for compound 4 lay 2.6-fold (0.41 log units) above the measured number; the measured number falls inside the stated range.
By their numbers in this assay, from the lowest: compound 4; then compound 3; then compounds 1 and 2 (each within the scatter of the next).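

In this assay, the aromatic carbon para to a large group accepts a substituent on the hydroxy-bearing core, and trifluoromethoxy there gives a 3.1-fold lower number from compound 3 to compound 4 (0.49 log units; beyond the scatter), so the number can be lowered further with the hydroxy group kept in place. Among the compounds shown, this is the only replacement of hydrogen by a group other than hydroxy that moves the number beyond the scatter, whereas chloro gave no change at the digits printed from compound 1 to compound 2 (within the scatter) on the core without the hydroxy group; those two steps start from different compounds, so they cannot be read as a direct comparison of the two groups. No measurement in hand explains why trifluoromethoxy lowers the number.

The compounds shown leave open whether the step is specific to trifluoromethoxy or would also appear with groups such as methoxy, trifluoromethyl, an amine or a carboxylic acid on the same carbon. They also leave open whether trifluoromethoxy would have any effect on the core without the hydroxy group, as no compound shown pairs the two in that way.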